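Pyrimidinyl for pyridinyl on the cytotoxicity series

This account rests on a few compounds, and the source may have more. Where it says the series, first, only, none or still open, it means among the compounds named here.

Compound 1 `Cc1ccc(C(=O)Nc2cc(-c3cnn(C)c3)cc(C(F)(F)F)c2)cc1Nc1cc(-c2cccnc2)ccn1` in a toxicity assay on H9c2 cells (Rattus norvegicus) for cytotoxicity, read by MTT assay, with a stated time of 48 h (a lower number here means a stronger inhibitor, a higher number a weaker inhibitor), reaches only the limit of > 80000 nM (the limit of > 80000 nM in this assay, at which 1 of the 2 values shown sits). Going by the values given here, compound 2 `Cc1ccc(C(=O)Nc2ccc(CN3CCN(C)CC3)c(C(F)(F)F)c2)cc1Nc1cc(-c2cccnc2)ccn1` gives the single number of the set in this assay, 9120 nM. Compound 3 `Cc1ccc(C(=O)Nc2ccc(CN3CCN(C)CC3)c(C(F)(F)F)c2)cc1Nc1cc(-c2cncnc2)ccn1` carries pyrimidin-5-yl in place of pyridin-3-yl on an aromatic carbon. Among the compounds with values here, no measured pair separates this exchange, so the expected step from compound 2 to compound 3 is a 1.3-fold higher number from compound 2 to compound 3 (0.12 log units; within the scatter), a change not expected to exceed the usual scatter. Compound 3 is thus estimated to give 12000 nM in this assay, within a range from 4000 nM to 40000 nM.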

Compound 3, half-maximal inhibitory concentration: 16700 nM
Estimate against measurement, compound 3: 1.4-fold (0.14 log units) below; the measured number falls inside the stated range.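

In this assay, pyrimidin-5-yl in place of pyridin-3-yl gives a 1.8-fold higher number from compound 2 to compound 3 (0.26 log units; within the scatter). Going by these compounds alone, this is the first step read at this position, opposite the ring nitrogen, and it shows that a ring with 2 hetero atoms can stand there without a step beyond the scatter. Nothing measured here gives a cause for this step.

The compounds shown leave open how a phenyl ring or a pyrimidin-5-yl ring carrying an amine would read at this position. They also leave open whether the same exchange reads alike on the core of compound 1.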